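A few compounds are considered here, and "the series" means these few. Any claim that something is new, unique, unknown or untested is made for them only; others in the source may bear on it.

In a toxicity assay on WI-38 cells (Homo sapiens) for cytotoxicity, read by MTT assay, with a stated time of 48 h (a higher number here means a weaker inhibitor, a lower number a stronger inhibitor), the measured compounds are: compound 1 `O=C(/C=C/c1ccc2c(c1)B(O)OC2)c1ccc(Cl)cc1`, 24700 nM; compound 2 `O=C(/C=C/c1ccc2c(c1)B(O)OC2)c1ccc(C(F)(F)F)cc1`, 22600 nM.

Compound 1 and compound 2 sit together: the step of a 1.1-fold lower number from compound 1 to compound 2 (0.04 log units; within the scatter) lies within the scatter, so neither stands apart from the other. Compound 3 `Cc1cccc(C(=O)/C=C/c2ccc3c(c2)B(O)OC3)c1` carries 3-methylphenyl in place of 4-chlorophenyl on a carbonyl carbon. Among the compounds with values here, the one measured step, a 1.1-fold lower number from compound 1 to compound 2 (0.04 log units; within the scatter), also exchanged a group on the carbonyl carbon's aromatic substituent and moved nothing beyond the scatter; no measured step exchanges 4-chlorophenyl for 3-methylphenyl directly. Compound 3 is therefore expected to show a step of a 1.0-fold higher number from compound 1 to compound 3 (0.01 log units; within the scatter), none beyond the scatter. The estimate for compound 3 is 25000 nM, ranging from 12000 nM to 52000 nM.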

Compound 3, half-maximal inhibitory concentration: 16700 nM
Beside the measured number, compound 3's estimate is 1.5-fold (0.18 log units) above it; the range from low to high includes it.
By their numbers in this assay, from the lowest: compounds 3, 2 and 1 (each within the scatter of the next).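

In this assay, exchanging 4-chlorophenyl for 3-methylphenyl on the carbonyl carbon gives a 1.5-fold lower number from compound 1 to compound 3 (0.17 log units; within the scatter). This extends the picture at this position: a ring carrying methyl and no chlorine also stays within the scatter of compound 1, so this change separates neither compound from the other. Nothing measured here offers an explanation for this result.

The compounds shown leave open whether an amine or a carboxylic acid on this aromatic ring would move the number beyond the scatter. They also leave open what a longer chain in place of the ring on the carbonyl carbon would do.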